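This account rests on a few compounds, and the source may have more. Where it says the series, first, only, none or still open, it means among the compounds named here.

Measured so far:
compound 1 `COc1cc(OC)c(OC)cc1/C=C/COC(=O)/C=C/c1ccc(OC)c(OC)c1` gives 100%
compound 2 `COc1cc(OC)c(OC)cc1/C=C/COC(=O)/C=C/c1c(OC)ccc(OC)c1OC` gives 100%

In a functional assay on the whole organism (strain Kunming) with Mus musculus as the target, with a stated time of 0.5 h, at a dose of 300 mg/kg by the intraperitoneal route (on this read-out lower numbers stand for a stronger effect and higher numbers for a weaker effect at the one dose given), compound 1 stands level with compound 2 at the digits shown; the two values lie within the scatter of each other, so no order between them can be drawn. Going by the values given here, no step between measured compounds is available.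

Compound 3 `COc1cc(OC)c(OC)cc1/C=C/COC(=O)/C=C/c1ccc(Cl)cc1` is not yet measured. It differs from compound 1 by 4-chlorophenyl in place of 3,4-dimethoxyphenyl on a double-bonded chain carbon bound to a double-bonded chain carbon. Among the compounds with values here, with no measured step to lean on, the expected step from compound 1 to compound 3 is no change at the digits printed from compound 1 to compound 3 (within the scatter), that is, nothing beyond the scatter, with any deviation more likely toward a stronger effect than a weaker one. Compound 3 is therefore estimated at 100%, within 75% to 100%.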

Compound 3, a percentage reported as activity, at one dose (the size of the read-out at that dose, not a potency): 100%
For compound 3 middle estimate and measured number coincide at the digits printed; the range from low to high includes it.
By their numbers in this assay, from the lowest: compounds 1, 2 and 3 (each within the scatter of the next).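

In this assay, putting 4-chlorophenyl in place of 3,4-dimethoxyphenyl on a double-bonded chain carbon bound to a double-bonded chain carbon gives no change at the digits printed from compound 1 to compound 3 (within the scatter). This is the first listed step at this position, and it shows that a chlorine-bearing ring without hydrogen-bond acceptors reads the same as the dimethoxy ring of compound 1. No measured finding on the compounds bears on this result.

As far as these compounds go, whether an amine or a carboxylic acid at this place would shift the read-out remains open. So does the effect of a longer chain there.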